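A few compounds are considered here, and "the series" means these few. Any claim that something is new, unique, unknown or untested is made for them only; others in the source may bear on it.

Compound 1 `CCc1ccccc1/C=C/C(=O)c1c(O)cc(OC)cc1OC` and compound 2 `COc1cccc(/C=C/C(=O)c2c(O)cc(OC)cc2OC)c1` were tested in a functional assay on B16-F10 cells (Mus musculus) for inhibition, with a stated time of 4 days; on this read-out higher numbers stand for weaker inhibition and lower numbers for stronger inhibition. Compound 1 gives 2500 nM, the lower of the two numbers, while compound 2 gives 3100 nM; the two values lie within the usual scatter of one another, so neither can be called stronger. Compound 3 `COc1cc(O)c(C(=O)/C=C/c2ccccc2C(C)C)c(OC)c1` has not yet been measured in this assay. It differs from compound 1 by methyl in place of hydrogen on a saturated chain carbon bound to an aromatic carbon and a saturated chain carbon. Among the measured compounds shown here, with no comparable step recorded, compound 3 is expected to sit close to compound 1, a step of no change at the digits printed from compound 1 to compound 3 (within the scatter) that does not exceed the scatter. The estimate for compound 3 is 2500 nM, likely between 1000 nM and 6000 nM.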

Compound 3, half-maximal inhibitory concentration: 2700 nM
Compound 3: the middle estimate sits 1.1-fold (0.03 log units) below what was measured; low and high end bracket the measured number.
By their numbers in this assay, from the lowest: compounds 1, 3 and 2 (each within the scatter of the next).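

Replacing ethyl with isopropyl gives a 1.1-fold higher number from compound 1 to compound 3 (0.03 log units; within the scatter) in this assay, so the extra methyl on this saturated chain carbon does not separate the two compounds. Among the compounds shown here, the earlier compounds offered no step between compounds differing in one place, so this is the first sign that this position tolerates a small added branch. Nothing available here explains this result. As far as these compounds go, whether a larger group at this place, such as tert-butyl, or a group of another kind, such as an amine or a carboxylic acid, would also leave the number within the scatter remains open.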